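A few compounds are considered here, and "the series" means these few. Any claim that something is new, unique, unknown or untested is made for them only; others in the source may bear on it.

Measured compounds:
- compound 1, `Cc1c(OCCCCOc2ccc(C(=O)O)cc2F)ccc(C(=O)CC(C)C)c1O`: 106%
- compound 2, `Cc1cc(OCCCCOc2ccc(C(=O)CC(C)C)c(O)c2C)ccc1C(=O)O`: 101%

In an ADME assay on a cell-free system (plasma, Rattus norvegicus) for metabolic stability, read by LC-MS, with a stated time of 60 min, tested at 100 uM (on this read-out lower numbers stand for a less stable compound and higher numbers for a more stable compound), compound 1 gives 106% and compound 2 gives 101%. Of the two numbers compound 2 is the lower one, but the step of a number 5 percentage points lower from compound 1 to compound 2 (within the scatter) lies within the scatter, so the two compounds cannot be separated on this read-out; both sit at essentially full recovery.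

Compound 3, `Cc1c(OCCCCOc2ccc(F)c(C(=O)O)c2)ccc(C(=O)CC(C)C)c1O`, is not yet measured. Its change from compound 2: 3-carboxy-4-fluorophenyl in place of 4-carboxy-3-methylphenyl on an oxygen on a saturated carbon. For the measured compounds named here, the only measured step that bears on this is the one from compound 1 to compound 2, a number 5 percentage points lower from compound 1 to compound 2 (within the scatter), which also exchanges the aryl group on the oxygen on the saturated carbon and produced no movement beyond the scatter. The step to compound 3 is of the same kind, so in this assay no change beyond the scatter is expected, in either direction.

Compound 3 is therefore expected to give about 102%, in a range from 88% to 115%, an estimated step of a number 1 percentage points higher from compound 2 to compound 3 (within the scatter).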

Compound 3, percent of the compound remaining: 101%
The estimate for compound 3 lay 1 percentage points above the measured number; measured number inside the range.
By their numbers in this assay, from the lowest: compounds 2, 3 and 1 (each within the scatter of the next).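

In this assay, 3-carboxy-4-fluorophenyl in place of 4-carboxy-3-methylphenyl on an oxygen on a saturated carbon gives no change at the digits printed from compound 2 to compound 3 (within the scatter) and, in place of 4-carboxy-2-fluorophenyl, gives a number 5 percentage points lower from compound 1 to compound 3 (within the scatter) at the same place. The earlier pair compared only aryl groups named as 4-carboxy, whereas the new group is named as 3-carboxy and carries its fluorine at 4, so this place now tolerates a change in the named position of the carboxy group as well as the exchange of methyl for fluorine, with all three compounds within the scatter of one another. Nothing measured here accounts for this flat read-out.

Going by these compounds, all three aryl groups still carry a carboxy group, so it remains open whether a primary amide, a nitrile or a tetrazole in its place would leave the percentage remaining just as unmoved. The butyl-type chain of four saturated carbons joining the two oxygens and the 3-methylbutanoyl ketone on the core also stay constant, so in this assay a shorter chain, or an amide in place of that ketone, remains an open question.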